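A few compounds are considered here, and "the series" means these few. Any claim that something is new, unique, unknown or untested is made for them only; others in the source may bear on it.

Compound 2 `N#CCCCCCc1cnc(C(=O)CCCCCCc2ccccc2)o1` gives 4 nM in an assay for inhibition of Fatty-acid amide hydrolase 1 (Rattus norvegicus), using a Dixon plot, with a stated time of 6 h (a higher number here means a weaker inhibitor, a lower number a stronger inhibitor), the lowest of the two numbers in hand. Its nearest neighbour is compound 1 `O=C(CCCCCCc1ccccc1)c1ncc(-c2ccc(CCl)cn2)o1`, which in this assay gives 24.6 nM; the two are separated by the step of a 6.2-fold lower number from compound 1 to compound 2 (0.79 log units; beyond the scatter). Compound 3 `O=C(CCCCCCc1ccccc1)c1ncc(CCCCCBr)o1` is compound 2 with bromo in place of cyano on a saturated chain carbon, five bonds along the chain from an aromatic carbon. For the measured compounds named here, none of the measured steps bears on this change: the only step in hand exchanges a ring-bearing group for an open chain at the aromatic carbon, whereas here the chain is kept and only its terminal group is exchanged, so that step offers no direct guide. With nothing to argue for a move beyond the scatter, the step of a 2.0-fold higher number from compound 2 to compound 3 (0.30 log units; within the scatter) is what is expected, and uncertainty is wide. Compound 3 is accordingly estimated at 8 nM in this assay, with a range from 2 nM to 30 nM.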

Compound 3, inhibition constant: 6 nM
Estimate against measurement, compound 3: 1.3-fold (0.12 log units) above; measured number inside the range.
By their numbers in this assay, from the lowest: compounds 2 and 3 (each within the scatter of the next); then compound 1.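

In this assay, exchanging the terminal group on the chain gives a 1.5-fold higher number from compound 2 to compound 3 (0.18 log units; within the scatter) and so does not separate bromo from cyano at this position, although only cyano carries a triple bond and a hydrogen-bond acceptor. A second open chain on the aromatic carbon also repeats the contrast with the ring-bearing group of compound 1: a 4.1-fold lower number from compound 1 to compound 3 (0.61 log units; beyond the scatter) runs in the same direction as a 6.2-fold lower number from compound 1 to compound 2 (0.79 log units; beyond the scatter) and so does not rest on the cyano end alone. Nothing in hand gives a reason for these numbers. The compounds shown leave open whether a terminal group of another kind, such as an amine or a carboxylic acid, would keep the number in the same range. They also leave open how a shorter or a longer chain would read with either bromo or cyano at its end.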